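The compounds below may be only part of what the source reports. "The series", "measured", "known", "first", "only" and "open" are said of these compounds alone.

Measured compounds:
- compound 1, `CCOc1cc(C(=O)Nc2ccc(Cl)c(-c3nc4ccccc4o3)c2)cc(OCC)c1OCC`: "not active" (no number reported)
- compound 2, `O=C(Nc1ccc(Cl)c(-c2nc3ccccc3[nH]2)c1)c1ccc(Cl)cc1`: 224 nM

In a functional assay on Shh Light II cells for inhibition of Sonic hedgehog protein (Mus musculus), read by reporter gene assay, with a stated time of 48 h, in the presence of a further agent that is not named here (a lower number here means a stronger inhibitor, a higher number a weaker inhibitor), compound 1 gives "not active" (no number reported), so no number stands behind it and it cannot be placed on a scale. Compound 2 differs from compound 1 in more than one place, so the two results can only be set side by side: compound 2 gives 224 nM in this assay, a measurable inhibition, where compound 1 shows none.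

Compound 3, `CCOc1cc(C(=O)Nc2ccc(Cl)c(-c3ncc[nH]3)c2)cc(OCC)c1OCC`, is the next step from compound 1: 1H-imidazol-2-yl in place of 1,3-benzoxazol-2-yl on an aromatic carbon. The new group carries a hydrogen-bond donor, as does the corresponding group in compound 2, which was measurable. Among the measured compounds shown here, since compound 1 has no number, no size of step can be set; the expectation is that compound 3 moves from the unmeasurable into a measurable but weak range, with a fair chance that this assay again reports no number. Compound 3 is estimated at 2000 nM, between 300 nM and 20000 nM.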

Compound 3, half-maximal inhibitory concentration: "not active" (no number reported)
No number was reported for compound 3; there is nothing to compare the estimate with.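

Among the compounds shown here, neither compound 1 nor compound 3 has a number in this assay, so no step between them can be read. No measured evidence bears on this result. On these data alone, whether 1H-imidazol-2-yl in place of 1,3-benzoxazol-2-yl changes inhibition at all stays open.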